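Swapping the Acetylphenyl Group for a Hydroxy-Methoxyphenyl Group

The compounds below may be only part of what the source reports. "The series", "measured", "known", "first", "only" and "open" are said of these compounds alone.

Compound 1, `COc1cc(-n2cnc3ccc(-c4cccc(F)c4)cc32)cc(OC)c1OC`: 5270 nM
Compound 2, `COc1cc(-n2cnc3ccc(-c4ccc(Cl)cc4Cl)cc32)cc(OC)c1OC`: > 10000 nM (a limit of the assay)
Compound 3, `COc1cc(-n2cnc3ccc(-c4ccc(C(C)=O)cc4)cc32)cc(OC)c1OC`: 2510 nM

Three compounds share one core and differ only in the aryl group attached to it. In a functional assay on A549 cells (Homo sapiens) for antiproliferative activity, read by MTT assay, with a stated time of 72 h (on this read-out lower numbers stand for stronger inhibition and higher numbers for weaker inhibition), compound 1 gives 5270 nM. Compound 2 reaches only a limit of the assay, > 10000 nM (the limit of > 10000 nM in this assay, at which 1 of the 3 values shown sits). Compound 3 gives 2510 nM, the lowest of the two numbers: there is a 2.1-fold lower number from compound 1 to compound 3 (0.32 log units; beyond the scatter), and an at least 3.9-fold lower number from compound 2 to compound 3 (0.60 log units; beyond the scatter).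

Compound 4, `COc1ccc(-c2ccc3ncn(-c4cc(OC)c(OC)c(OC)c4)c3c2)cc1O`, differs from compound 3 in one place: 3-hydroxy-4-methoxyphenyl in place of 4-acetylphenyl on an aromatic carbon. Going by the values given here, no measured step involves a hydroxy or methoxy group on this ring, so there is no direct guide. The steps measured so far on this ring ran from within the scatter to modest, which suggests a change of similar size here. Compound 4 is therefore expected to give about 1500 nM, with a range from 300 nM to 8000 nM. The expected step, a 1.7-fold lower number from compound 3 to compound 4 (0.22 log units; within the scatter), would lie within the scatter.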

Compound 4, half-maximal inhibitory concentration: 200 nM
Compound 4: middle estimate off by 7.5-fold (0.88 log units), on the high side; the whole stated range lies above it.
By their numbers in this assay, from the lowest: compound 4; then compound 3; then compound 1. At a limit, above all of these: compound 2.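

In this assay, going by these compounds alone, this position proves far more sensitive than the earlier compounds showed, with a 13-fold lower number from compound 3 to compound 4 (1.10 log units; beyond the scatter) and a 26-fold lower number from compound 1 to compound 4 (1.42 log units; beyond the scatter), whereas the one earlier step between two exact numbers, a 2.1-fold lower number from compound 1 to compound 3 (0.32 log units; beyond the scatter), was much smaller. The step from compound 2 is an at least 50-fold lower number from compound 2 to compound 4 (1.69 log units; beyond the scatter), and that figure is only a floor: the limit of > 10000 nM in this assay, at which 1 of the 4 values shown sits.

Compound 4 alone carries a hydroxy and a methoxy group on this ring, and it alone gives a number this low, but nothing shown here explains the change.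

On these data alone, it remains open whether the hydroxy group, the methoxy group or the two together account for the drop. A phenyl ring carrying only one of them would help to settle this, and an amine or a carboxylic acid in place of the hydroxy group would test how specific that group is.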